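Ethyl to tert-Butyl on the Shared Core

This account rests on a few compounds, and the source may have more. Where it says the series, first, only, none or still open, it means among the compounds named here.

Measured compounds:
compound 1, `CCc1cc(N)c2cc(NC(=O)/C=C/c3ccc(C(F)(F)F)cc3)ccc2n1`: 110 nM
compound 2, `CCCc1cc(N)c2cc(NC(=O)/C=C/c3ccc(F)cc3)ccc2n1`: 200 nM

Two compounds carry the shared core with an amino group and a cinnamamide on a fused bicyclic system, differing in the alkyl group next to the ring nitrogen and in the substituent on the distal phenyl ring. In a functional assay on HEK293 cells for activation of melanin-concentrating hormone receptor 1 (Homo sapiens), read by inositol phosphate accumulation (on this read-out higher numbers stand for an effect only at larger amounts of compound and lower numbers for an effect already at smaller amounts), compound 1 gives 110 nM, the lower of the two numbers; in this assay compound 2 gives 200 nM, a value that lies within the scatter of compound 1, so the two cannot be told apart on these data. Among the measured compounds shown here, compounds 1 and 2 differ in two places at once, so no single structural step between measured compounds can be read from them.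

Compound 3, `CC(C)(C)c1cc(N)c2cc(NC(=O)/C=C/c3ccc(C(F)(F)F)cc3)ccc2n1`, is not yet measured. It differs from compound 1 in one place: tert-butyl in place of ethyl on an aromatic carbon.

For the measured compounds named here, nothing measured here isolates the effect of a larger branched alkyl at this position; the only guidance is that an ethyl and a propyl at the same place both give numbers of similar size. On that basis compound 3 is expected to stay close to compound 1, with a step of a 1.4-fold higher number from compound 1 to compound 3 (0.13 log units; within the scatter) that is expected not to exceed the scatter. Compound 3 is therefore estimated at 150 nM, within a range from 50 nM to 450 nM.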

Compound 3, half-maximal effective concentration: 29 nM
Compound 3: middle estimate off by 5.2-fold (0.71 log units), on the high side; measured number below the stated range.
By their numbers in this assay, from the lowest: compound 3; then compounds 1 and 2 (each within the scatter of the next).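

In this assay, putting tert-butyl in place of ethyl on the aromatic carbon next to the ring nitrogen gives a 3.8-fold lower number from compound 1 to compound 3 (0.58 log units; beyond the scatter), which shows that the number responds to the alkyl group at this position. Compounds 1 and 2 could not show this, since they differ in two places at once; here the trifluoromethyl group on the distal phenyl ring and the rest of the shared core stay the same, so the step belongs to the alkyl exchange alone. Nothing available accounts for the direction or the size of this step.

The compounds shown leave open whether branching or simply a greater number of carbons goes with the lower number, a question that isopropyl, cyclopropyl or a longer straight chain such as n-butyl at the same place on the core of compound 1 would address. On these data alone, it also remains open whether tert-butyl has a similar effect with the fluorine of compound 2 on the distal ring, and how a group carrying oxygen or nitrogen, such as methoxymethyl or an aminomethyl, would fare at this position.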